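Half-life notes on compound 2 and compound 3

The compounds below may be only part of what the source reports. "The series", "measured", "known", "first", "only" and "open" are said of these compounds alone.

Measured so far in an ADME assay on the whole organism (plasma, Mus musculus, strain CD1) for metabolic stability, with a stated time of 8 h, at a dose of 0.3 mg/kg by the intravenous route; a lower number here means that the compound disappears faster, a higher number that the compound lasts longer
- compound 1 `CN(C)c1noc(-c2cccc(CN(C)c3ccc4[nH]nc(C(=O)O)c4c3)c2O)n1` gives 3.3 h
- compound 2 `CC(C)c1noc(-c2cccc(CNc3ccc4[nH]nc(C(=O)O)c4c3)c2O)n1` gives 0.4 h

Compound 2 has the lower of the two numbers, and its gap to compound 1 lies beyond the scatter. Compound 3 `Cc1nc(-c2cccc(CNc3ccc4[nH]nc(C(=O)O)c4c3)c2O)sc1C` differs from compound 2 (4,5-dimethyl-1,3-thiazol-2-yl in place of 3-isopropyl-1,2,4-oxadiazol-5-yl on an aromatic carbon) by carrying 4,5-dimethyl-1,3-thiazol-2-yl in place of 3-isopropyl-1,2,4-oxadiazol-5-yl on an aromatic carbon, ortho to a hydroxy group. Among the compounds with values here, no measured pair isolates this change in this assay, so no step beyond the scatter is expected. The estimated 1.5-fold higher number from compound 2 to compound 3 (0.18 log units; within the scatter) is expected to stay within the scatter. For compound 3 the expected half-life is 0.6 h as an estimate (0.2 h to 2 h).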

Compound 3, half-life: 3.3 h
Beside the measured number, compound 3's estimate is 5.5-fold (0.74 log units) below it; measured number above the stated range.
By their numbers in this assay, from the lowest: compound 2; then compounds 1 and 3 (each within the scatter of the next).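

In this assay this position, on an aromatic carbon ortho to a hydroxy group, is sensitive to the choice of five-membered ring: 4,5-dimethyl-1,3-thiazol-2-yl in place of 3-isopropyl-1,2,4-oxadiazol-5-yl gives an 8.3-fold higher number from compound 2 to compound 3 (0.92 log units; beyond the scatter). Within the data shown here, this is the only change in one place that can be read, so it rests on a single pair. Nothing available accounts for the step.

Still open, as far as these compounds go, is whether the thiazole ring or its two methyl groups carry the step. An unsubstituted thiazol-2-yl at this position would separate the two.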